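Benzyl in place of isobutyl on the ring nitrogen

This account rests on a few compounds, and the source may have more. Where it says the series, first, only, none or still open, it means among the compounds named here.

Compound 1 `Nc1c(C(=O)N[C@H]2CC[C@@H](c3ccc(OCc4ccccc4)cc3)CC2)[nH]c(=O)[nH]c1=O`: 21 nM
Compound 2 `O=C(N[C@H]1CC[C@@H](c2ccccc2)CC1)c1[nH]c(=O)[nH]c(=O)c1O`: 26 nM
Compound 3 `CC(C)Cn1c(=O)[nH]c(C(=O)N[C@H]2CC[C@@H](c3ccccc3)CC2)c(O)c1=O`: 59 nM

These three compounds were tested in an assay on cells for inhibition of endothelial lipase (Homo sapiens), read by LC-MS, with stated times of 10 min and 30 min; on this read-out higher numbers stand for weaker inhibition and lower numbers for stronger inhibition. Compound 3 gives the highest number of the three, with compound 2 nearest and compound 1 furthest away; both gaps lie beyond the scatter, so compound 3 is the weakest inhibitor among them. Going by the values given here, the one step that involves the nitrogen substituent is a 2.3-fold higher number from compound 2 to compound 3 (0.36 log units; beyond the scatter), where a hydrogen on an aromatic nitrogen became isobutyl.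

Compound 4 `O=C(N[C@H]1CC[C@@H](c2ccccc2)CC1)c1[nH]c(=O)n(Cc2ccccc2)c(=O)c1O` has not yet been measured. It differs from compound 3 by phenyl in place of isopropyl on a saturated chain carbon bound to an aromatic nitrogen. Among the compounds with values here, no measured step swaps an alkyl group for a phenyl at this position, so the only guide is that changing the nitrogen substituent in the step from compound 2 to compound 3 shifted the number only modestly. Exchanging one substituent for another at the same place is therefore expected to move the number little, if at all, beyond the scatter, in either direction. The estimated step is a 1.0-fold higher number from compound 3 to compound 4 (0.01 log units; within the scatter). Compound 4 is expected to give about 60 nM in this assay, in a range from 20 nM to 180 nM.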

Compound 4, half-maximal inhibitory concentration: 117 nM
Compound 4: the middle estimate sits 2.0-fold (0.29 log units) below what was measured; low and high end bracket the measured number.
By their numbers in this assay, from the lowest: compounds 1 and 2 (each within the scatter of the next); then compounds 3 and 4 (each within the scatter of the next).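

In this assay the exchange of isobutyl for benzyl on the ring nitrogen gives a 2.0-fold higher number from compound 3 to compound 4 (0.30 log units; within the scatter) and so leaves compound 3 and compound 4 indistinguishable. An aromatic ring can therefore sit on this saturated chain carbon without a readable change from the branched alkyl group. Replacing the hydrogen on that nitrogen with benzyl gives a 4.5-fold higher number from compound 2 to compound 4 (0.65 log units; beyond the scatter) and that step lies beyond the scatter, as does the isobutyl step, so among compound 2, compound 3 and compound 4 the compound with hydrogen on this nitrogen gives the lowest number.

On these data alone, how a longer chain such as phenethyl, or an amine or carboxylic acid at the end of the chain, would read at this nitrogen remains open. No measurement at hand explains why either substituent gives a higher number than hydrogen.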